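Replacing cyclobutylmethyl on the carbonyl of compound 3

The source may report more compounds than this note shows. Statements on the series, on what has been measured and on what is new or still open speak of the compounds shown alone.

For the measured compounds named here, compound 3 (`NS(=O)(=O)c1ccc(-c2cc(C(=O)CC3CCC3)nn2-c2ccc(Cl)cc2)cc1`) gives 4300 nM in a physicochemical assay for solubility, read by HPLC, in phosphate buffer, measured as kinetic solubility, at pH 7.4 (on this read-out lower numbers stand for lower solubility and higher numbers for higher solubility), the lowest of the three numbers so far. Compound 1 (`CCCC(=O)c1cc(-c2ccc(S(N)(=O)=O)cc2)n(-c2ccc(Cl)cc2)n1`) gives 25800 nM, and compound 2 (`CC(=O)c1cc(-c2ccc(S(N)(=O)=O)cc2)n(-c2ccc(Cl)cc2)n1`) gives 86800 nM.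

The next change leads to compound 4 (`NS(=O)(=O)c1ccc(-c2cc(C(=O)N3CC4CC4C3)nn2-c2ccc(Cl)cc2)cc1`): a group of 6 heavy atoms (5 carbon, 1 nitrogen; one three-membered non-aromatic ring of carbon only, one five-membered non-aromatic ring with 1 hetero atom) in place of a group of 5 heavy atoms (5 carbon; one four-membered non-aromatic ring of carbon only), on a carbonyl carbon. It sits on a carbonyl carbon, the same carbonyl that carries the differences among the measured compounds.

Going by the values given here, three measured steps bear on it, all beyond the scatter: a 3.4-fold higher number from compound 1 to compound 2 (0.53 log units; beyond the scatter), a 6.0-fold lower number from compound 1 to compound 3 (0.78 log units; beyond the scatter) and a 20-fold lower number from compound 2 to compound 3 (1.31 log units; beyond the scatter). The first two are modest and the third is large. None of them brings a ring with a hetero atom onto the carbonyl carbon, so they indicate the size of step this position can show but give only weak guidance on direction.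

With compound 3 the lowest at 4300 nM, a modest rise is expected, though not firmly. The expected change is a 2.8-fold higher number from compound 3 to compound 4 (0.45 log units; beyond the scatter). Compound 4 is estimated at 12000 nM, with an expected range of 3000 nM to 45000 nM.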

Compound 4, solubility: 36600 nM
Beside the measured number, compound 4's estimate is 3.1-fold (0.48 log units) below it; the range from low to high includes it.
By their numbers in this assay, from the lowest: compound 3; then compounds 1 and 4 (each within the scatter of the next); then compound 2.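

Up to compound 3 the number in this assay fell as the group on the carbonyl carbon grew, but compound 4 goes against that order: an 8.5-fold higher number from compound 3 to compound 4 (0.93 log units; beyond the scatter) comes with the largest group so far, the first to hold a ring with a hetero atom. The step of a 1.4-fold higher number from compound 1 to compound 4 (0.15 log units; within the scatter) lies within the scatter, while a 2.4-fold lower number from compound 2 to compound 4 (0.38 log units; beyond the scatter) leaves compound 2 with the highest of the four numbers. No measurement at hand accounts for these steps.

Still open, from the compounds shown here alone, is whether the step from compound 3 belongs to the nitrogen on the carbonyl carbon or to the particular rings of compound 4. A plain pyrrolidine or an open-chain diethylamine on the same carbonyl carbon would separate those two readings.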